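The source may hold more compounds than are shown below. What is called first, only, known or untested is meant among the compounds shown, and "the series" means these compounds.

Measured so far in an assay on isolated protein for inhibition of Amine oxidase [flavin-containing] B (Homo sapiens), read by fluorescence and Amplex Red, with a stated time of 15 min; on this read-out lower numbers stand for stronger inhibition and higher numbers for weaker inhibition:

compound 1 `C#CCN(Cc1cn(-c2cc(NC(=S)NCC)ncn2)cn1)C(C)=O` gives > 50000 nM, a limit of this assay.
compound 2 `C#CCN(Cc1ccccc1)Cc1cn(-c2cc(NC(=S)NCC)ncn2)cn1` gives > 50000 nM, likewise a limit.
compound 3 `C#CCN(CC#C)Cc1cn(-c2cc(NC(=S)NCC)ncn2)cn1` gives > 50000 nM, again a limit.

Compound 1 thus stands only at a limit, with no number of its own; the same holds for the two other measured compounds, all three sitting at the limit of > 50000 nM in this assay, at which 3 of the 3 values shown sit. The step to compound 4 `C#CCNCCCc1cn(-c2cc(NC(=S)NCC)ncn2)cn1` is a group of 6 heavy atoms (5 carbon, 1 nitrogen; no ring) in place of a group of 7 heavy atoms (5 carbon, 1 nitrogen, 1 oxygen; no ring), on a saturated chain carbon bound to an aromatic carbon. Of the measured steps, the two that touch the same amine nitrogen are a step that the two limits leave unreadable from compound 1 to compound 2 and a step that the two limits leave unreadable from compound 1 to compound 3; the third, a step that the two limits leave unreadable from compound 2 to compound 3, is equally unreadable. None of these gives a size or a direction, so they offer no anchor for this assay beyond showing that three variations at that nitrogen stay at the limit. The change to compound 4 removes the carbonyl and lengthens the chain, a different kind of step from any measured one. In this assay compound 4 is estimated at 20000 nM, within 2000 nM to 100000 nM, with a real chance that only a limit is again reported. The expected step is an at least 2.5-fold lower number from compound 1 to compound 4 (0.39 log units; beyond the scatter), which cannot be sized against the limits shown.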

Compound 4, half-maximal inhibitory concentration: > 50000 nM
Compound 4: a limit, no number; the forecaster's own chance of this, stated with the estimate: 55%; at least 2.5-fold (0.39 log units) between middle value and limit.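

In this assay compound 4 gives > 50000 nM, a limit and not a number, so the steps to it from compound 1 and compound 3 cannot be read. The compounds shown leave open whether any of these changes alters inhibition at all, with every value at one limit: the limit of > 50000 nM in this assay, at which 4 of the 4 values shown sit.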